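A few compounds are considered here, and "the series" means these few. Any claim that something is new, unique, unknown or untested is made for them only; others in the source may bear on it.

Measured in an ADME assay on BJ cells (Homo sapiens) for cytotoxicity, with a stated time of 72 h (on this read-out higher numbers stand for an effect only at larger amounts of compound and lower numbers for an effect already at smaller amounts), all three values being limits:
- Compound 1 `C=C[C@@](C)(/C=C/c1ccc(OC)cc1)CCC=C(C)C`: > 36600 nM
- Compound 2 `C=C[C@@](C)(/C=C/c1ccc(O)cc1)CCCO`: > 36600 nM
- Compound 3 `C=C[C@@](C)(/C=C/c1ccc(O)c(/C=C/C(=O)c2ccccc2)c1)CCC=C(C)C`: > 20000 nM

In this assay compound 3 gives > 20000 nM, which is a limit and not a number. Within the data shown here, no compound has yet given a measured number, so compound 3 cannot be ranked against compound 1 or compound 2.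

Compound 4 `C=C[C@@](C)(/C=C/c1ccc(O)c(/C=C/C(N)=O)c1)CCC=C(C)C` has amino in place of phenyl on a carbonyl carbon, a change from benzoyl to carbamoyl: amino in place of phenyl on a carbonyl carbon.

Among the measured compounds shown here, the series offers no measured step to size this change. The expectation rests on compound 3 with its limit of > 20000 nM and on the absence of any measured effect in the other two compounds. No shift beyond the scatter is expected in this assay, and no direction can be assigned. The expected change is a step that the limit leaves unreadable from compound 3 to compound 4.

Compound 4 is estimated at 25000 nM, with an expected range of 8000 nM to 50000 nM.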

Compound 4, half-maximal effective concentration: > 36600 nM
Compound 4 was reported as a limit (the forecaster's own chance of this, stated with the estimate: 75%); middle value at least 1.4-fold (0.16 log units) from the limit.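

In this assay compound 3 gives > 20000 nM, a limit. Compound 4 gives > 36600 nM, also a limit. No step can be read between compound 3 and compound 4 for the change from benzoyl to carbamoyl. The compounds shown leave open at what concentration, if any, a half-maximal effect would appear.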